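This account rests on a few compounds, and the source may have more. Where it says the series, first, only, none or still open, it means among the compounds named here.

Measured so far:
- compound 1, `O=C1/C(=C/c2ccccc2)CCC/C1=C\c1cccc(O)c1`: 65.1% in an assay on isolated protein for inhibition of Alpha glucosidase (Homo sapiens), with stated times of 5 min and 15 min, tested at 50 uM; a higher number here means more inhibition at the concentration tested (going by the name of the read-out), a lower number less inhibition
- compound 2, `O=C1/C(=C/c2ccccc2)CCC/C1=C\c1cccc(Cl)c1Cl`: 44% in this assay

Compound 2 stands lowest of the two numbers in this assay. Its nearest neighbour is compound 1, whose inhibition is higher by a gap that lies beyond the usual scatter, so the two compounds are distinguishable on the numbers shown.

Compound 3, `O=C1/C(=C/c2ccccc2)CCC/C1=C\c1ccccc1Cl`, is the next candidate for this assay. Its difference from compound 2 is hydrogen in place of chloro on an aromatic carbon. The remaining chloro group of compound 2 is kept.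

For the measured compounds named here, no pair of measured compounds differs in a single place, so the series itself offers no measured step for the removal of one chloro group. For this assay the expectation is a step of modest size, most likely within the scatter, with a slight lean upward rather than downward. Compound 3 is expected to give about 50%, estimated to lie between 32% and 68%. This estimate amounts to an expected step of a number 6 percentage points higher from compound 2 to compound 3 (within the scatter).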

Compound 3, a percentage reported as inhibition, at one concentration (the size of the read-out at that concentration, not a potency): 43%
Estimate against measurement, compound 3: 7 percentage points above; the range from low to high includes it.
By their numbers in this assay, from the lowest: compounds 3 and 2 (each within the scatter of the next); then compound 1.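

Taking away the chloro group that stands ortho to the remaining chloro group gives a number 1 percentage points lower from compound 2 to compound 3 (within the scatter) in this assay, so at this position the change does not register as a difference in inhibition at the concentration tested. The exchange on the double-bonded chain carbon reads differently: 2-chlorophenyl in place of 3-hydroxyphenyl gives a number 22.1 percentage points lower from compound 1 to compound 3 (beyond the scatter), which places the readable change in the identity of this aryl group rather than in the second chloro group. Nothing available here accounts for either step.

The compounds shown leave open how much of the larger step belongs to the loss of the hydroxy group and how much to the arrival of the chloro group. Also open, on these data alone, is how an amine or a carboxylic acid on this aromatic ring would read in this assay.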